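Imide series: amino versus 3-chlorophenyl on the ring nitrogen

The source may hold more compounds than are shown below. What is called first, only, known or untested is meant among the compounds shown, and "the series" means these compounds.

Measured so far:
- compound 1 `NN1C(=O)C(c2ccccc2)CC(c2ccccc2)C1=O` gives 10 mg/kg in a functional assay on the whole organism (strain Swiss albino) with Mus musculus as the target, in the maximal electroshock model, with a stated time of 2 h; a higher number here means that more compound is needed for the effect, a lower number that less compound is needed
- compound 2 `O=C1C(c2ccccc2)CC(c2ccccc2)C(=O)N1c1cccc(Cl)c1` reaches only the limit > 100 mg/kg in this assay
- compound 3 `NN1C(=O)C(c2ccccc2Cl)CC(c2ccccc2Cl)C1=O` gives 11.2 mg/kg in this assay

Compound 1 and compound 3 give numbers within the usual scatter of each other, so no order between them is claimed. The difference between their two cores is not broken down here.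

Among the measured compounds shown here, the one measured step is an at least 10-fold higher number from compound 1 to compound 2 (1.00 log units; beyond the scatter), made by the change (3-chlorophenyl in place of amino on an amide-type nitrogen in a ring). The size of that step is bounded by the limit of > 100 mg/kg in this assay, at which 1 of the 3 values shown sits, so only its lower bound is known.

Compound 4 `O=C1C(c2ccccc2Cl)CC(c2ccccc2Cl)C(=O)N1c1cccc(Cl)c1` is not yet measured. It arises from compound 3 by 3-chlorophenyl in place of amino on an amide-type nitrogen in a ring. For the measured compounds named here, this is the same kind of change as the one from compound 1 to compound 2; the surroundings differ in that the two ring atoms bear 2-chlorophenyl groups in compound 3 but phenyl groups in compound 1.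

For this assay the expected step is a 13-fold higher number from compound 3 to compound 4 (1.13 log units; beyond the scatter), set beside the earlier one. This expectation rests on an at least 10-fold higher number from compound 1 to compound 2 (1.00 log units; beyond the scatter) and on (the limit of > 100 mg/kg in this assay, at which 1 of the 3 values shown sits), with the added uncertainty that the ring substituents around the place are not the same. For compound 4 the estimated value is 150 mg/kg, with an expected span from 50 mg/kg to 450 mg/kg.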

Compound 4, dose for half-maximal effect: 60.2 mg/kg
For compound 4 the middle estimate is 2.5-fold (0.40 log units) above the measured one, within the range that was stated.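

In this assay, 3-chlorophenyl in place of amino on the ring nitrogen gives a higher number on the core bearing 2-chlorophenyl groups too, with a 5.4-fold higher number from compound 3 to compound 4 (0.73 log units; beyond the scatter), so on both cores shown the change goes in the same direction and beyond the scatter. This does not show that the change has the same size on the two cores: the same change on two cores in this assay, an at least 10-fold higher number (1.00 log units; beyond the scatter) from compound 1 to compound 2 and a 5.4-fold higher number (0.73 log units; beyond the scatter) from compound 3 to compound 4; the limit leaves it open whether they differ. Two cores are also a narrow base for any rule about carrying the change further, and the step on the core of compound 1 rests on a limit of the assay, held by compound 2: the limit of > 100 mg/kg in this assay, at which 1 of the 4 values shown sits.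

The compounds shown leave open how other groups on the ring nitrogen would read in this assay, for example a methyl group, a hydroxyl group, a dimethylamino group or an unsubstituted phenyl ring, and so whether the higher numbers follow from losing amino or from bringing in 3-chlorophenyl in particular. They also leave open whether the step would persist on a core carrying other groups at the two ring atoms, such as methoxyphenyl or a carboxylic acid.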